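Working notes: aryl exchange in the L02 cytotoxicity series

The compounds below may be only part of what the source reports. "The series", "measured", "known", "first", "only" and "open" are said of these compounds alone.

Values in an ADME assay on L02 cells (Homo sapiens) for cytotoxicity, read by MTT assay, with a stated time of 24 h; on this read-out higher numbers stand for weaker inhibition and lower numbers for stronger inhibition:
- compound 1 (`COc1cc(/C=C2\CN(C)C/C(=C\c3ccccc3F)C2=O)cc(OC)c1`) gives 11900 nM
- compound 2 (`COc1cc(/C=C2\CN(C)C/C(=C\c3ccc(Cl)cc3)C2=O)cc(OC)c1`) gives 18900 nM
- compound 3 (`CN1C/C(=C\c2ccc(Cl)cc2)C(=O)/C(=C/c2cccc([N+](=O)[O-])c2)C1`) gives > 20000 nM, a limit and not a number

Compound 3 has only a limit on these numbers: the limit of > 20000 nM in this assay, at which 1 of the 3 values shown sits.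

Compound 4 (`CN1C/C(=C\c2cccc(Br)c2)C(=O)/C(=C/c2cccc([N+](=O)[O-])c2)C1`) has not yet been measured. It differs from compound 3 by 3-bromophenyl in place of 4-chlorophenyl on a double-bonded chain carbon bound to a double-bonded ring carbon, which is 3-bromophenyl in place of 4-chlorophenyl on a double-bonded chain carbon bound to a double-bonded ring carbon.

Within the data shown here, one measured step bears on this change, as it exchanges one substituted phenyl group for another at the same place: a 1.6-fold higher number from compound 1 to compound 2 (0.20 log units; within the scatter). That step lies within the scatter. It also comes from a pair whose remaining structure differs from that of compound 3, so it is only indirect support.

No step beyond the scatter is therefore expected in this assay, in either direction, and a second limit is quite possible. The expected change is a step that the limit leaves unreadable from compound 3 to compound 4, an estimate that rests on a limit at its starting end. For compound 4 the estimated value is 22000 nM, with an expected range from 10000 nM to 50000 nM.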

Compound 4, half-maximal inhibitory concentration: 8070 nM
For compound 4 the middle estimate is 2.7-fold (0.44 log units) above the measured one; the measured number lies below the stated range.
By their numbers in this assay, from the lowest: compounds 4, 1 and 2 (each within the scatter of the next, the first and the last beyond it). At a limit, above all of these: compound 3.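

In this assay, 3-bromophenyl in place of 4-chlorophenyl on a double-bonded chain carbon bound to a double-bonded ring carbon gives an at least 2.4-fold lower number from compound 3 to compound 4 (0.39 log units; beyond the scatter). This shows that an exchange of one substituted phenyl group for another at this place can produce a step beyond the scatter, which the earlier exchange, a 1.6-fold higher number from compound 1 to compound 2 (0.20 log units; within the scatter), did not show, and it does so with the same counts of heavy atoms, hydrogen-bond donors and hydrogen-bond acceptors in the leaving and entering groups. The size of the new step is only a lower bound: the limit of > 20000 nM in this assay, at which 1 of the 4 values shown sits.

Since chlorine gives way to bromine and the substitution pattern on the phenyl ring changes in the same exchange, the compounds shown leave open which of the two goes with the step. Also open, on these data alone, is how a phenyl group carrying an amine or a carboxylic acid in place of the halogen would read at this place in this assay.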